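Nitro in place of fluoro: expected cytotoxicity

The source may hold more compounds than are shown below. What is called first, only, known or untested is meant among the compounds shown, and "the series" means these compounds.

The series is tested in an ADME assay on NIH3T3 cells (Mus musculus) for cytotoxicity, read by MTT assay, with a stated time of 24 h; a lower number here means a stronger inhibitor, a higher number a weaker inhibitor. Going by the values given here, compound 2 `O=C(CSc1nnnn1-c1ccccc1)N/N=c1/scc(-c2ccc(Cl)cc2)n1-c1ccccc1` gives 313 ug/mL, and compound 3 `O=C(CSc1nnnn1-c1ccccc1)N/N=c1/scc(-c2ccc(F)cc2)n1-c1ccccc1` gives 207 ug/mL; the only measured single change, a 1.5-fold lower number from compound 2 to compound 3 (0.18 log units; within the scatter), stays within the scatter. Compound 1 `Cc1nnc(SCC(=O)N/N=c2/scc(-c3ccc([N+](=O)[O-])cc3)n2-c2ccccc2)s1` gives 177 ug/mL, and compound 3 lies within the scatter of both compound 1 and compound 2, so no ordering of the three is supported. Compound 4 `O=C(CSc1nnnn1-c1ccccc1)N/N=c1/scc(-c2ccc([N+](=O)[O-])cc2)n1-c1ccccc1` differs from compound 3 by nitro in place of fluoro on an aromatic carbon. Among the compounds with values here, no measured step covers this exchange directly; the one measured step is small, and compound 1, which already carries the nitro group but differs elsewhere in the molecule, sits close to compound 3. Compound 4 is therefore expected to show no step beyond the scatter, a 1.1-fold lower number from compound 3 to compound 4 (0.04 log units; within the scatter). The estimate for compound 4 is 190 ug/mL, with a range from 90 ug/mL to 400 ug/mL.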

Compound 4, half-maximal inhibitory concentration: 14.3 ug/mL
Compound 4: middle estimate off by 13-fold (1.12 log units), on the high side; the whole stated range lies above it.
By their numbers in this assay, from the lowest: compound 4; then compounds 1, 3 and 2 (each within the scatter of the next).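

In this assay this position on an aromatic carbon, para to a large group, is not indifferent to its substituent: nitro in place of fluoro gives a 14-fold lower number from compound 3 to compound 4 (1.16 log units; beyond the scatter) and nitro in place of chloro gives a 22-fold lower number from compound 2 to compound 4 (1.34 log units; beyond the scatter) while the exchange between the two halogens gave only a 1.5-fold lower number from compound 2 to compound 3 (0.18 log units; within the scatter) within the scatter. The group on the sulfur also matters with nitro held constant, as 1-phenyl-1H-tetrazol-5-yl in place of 5-methyl-1,3,4-thiadiazol-2-yl gives a 12-fold lower number from compound 1 to compound 4 (1.09 log units; beyond the scatter) in this series.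

Going by these compounds, whether an amine or a carboxylic acid at this position would give a similar step remains open. Nothing shown gives a cause for these steps.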